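Anilino to benzylsulfanyl on the shared core

This account rests on a few compounds, and the source may have more. Where it says the series, first, only, none or still open, it means among the compounds named here.

The study compares three compounds on a single read-out, the dose for half-maximal effect in a functional assay on the whole organism (Pleural cavity) with Rattus norvegicus as the target; a higher number here means that more compound is needed for the effect, a lower number that less compound is needed. In this assay compound 1 `OC[C@H]1OC(n2cnc3c(Nc4ccccc4)nccc32)[C@H](O)[C@@H]1O` gives only a limit of the assay, > 9 mg/kg. Compound 2 `OCCNc1[nH]ccc2ncnc1-2` likewise gives only a limit in this assay, > 9 mg/kg. Among the compounds with values here, both values therefore sit at the limit of > 9 mg/kg in this assay, at which 2 of the 2 values shown sit, and no step between compounds that differ in a single place has been measured, so compound 1 stands on the numbers only as a limit, with no measured neighbour to set its place more closely.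

Compound 3 `OC[C@H]1OC(n2cnc3c(SCc4ccccc4)nccc32)[C@H](O)[C@@H]1O` differs from compound 1 by benzylsulfanyl in place of anilino on an aromatic carbon. Within the data shown here, since no measured step informs this exchange, the step from compound 1 to compound 3 in this assay is expected to be none beyond the scatter, which the estimate a step that the limit leaves unreadable from compound 1 to compound 3 expresses. Compound 3 is accordingly estimated at 12 mg/kg, with a range from 5 mg/kg to 30 mg/kg, and it is expected that the assay will most likely again report only a limit for compound 3.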

Compound 3, dose for half-maximal effect: 9 mg/kg
The estimate for compound 3 lay 1.3-fold (0.12 log units) above the measured number; low and high end bracket the measured number.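

Compound 3, with benzylsulfanyl on the aromatic carbon next to the ring nitrogen, is the only one of the compounds shown that gives a number in this assay, at 9 mg/kg. Compound 1, with anilino at the same place, gives only a limit, > 9 mg/kg. The exchange removes the hydrogen-bond donor of anilino and still leaves a measurable dose, and it reads as a number no higher from compound 1 to compound 3 (the limit leaves the size open).

Whether benzylamino or phenylsulfanyl at this position would behave like benzylsulfanyl or like anilino stays open, so the compounds shown do not separate the effect of the sulfur from that of the benzyl part. How far compound 1 really lies from compound 3 also stays unread, because the comparison rests on a value that is only a limit: the limit of > 9 mg/kg in this assay, at which 2 of the 3 values shown sit.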